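Gem-Dimethyl on the Piperazine: Expectation for Compound 4

The source may report more compounds than this note shows. Statements on the series, on what has been measured and on what is new or still open speak of the compounds shown alone.

Measured compounds in a functional assay on CCRF-CEM cells for antagonist activity at C-X-C chemokine receptor type 4 (Homo sapiens), read by calcium flux, with stated times of 25 min and 90 s; on this read-out lower numbers stand for stronger inhibition and higher numbers for weaker inhibition:
Compound 1 `CN(C[C@@H]1Cc2c(cccc2N2CCNCC2)CN1)[C@H]1CCCc2cccnc21` gives 313 nM.
Compound 2 `CN(C[C@H]1Cc2c(cccc2N2CCNCC2)CN1)[C@H]1CCCc2cccnc21` gives 6.08 nM.
Compound 3 `FC1(F)CCC(CN(C[C@H]2Cc3c(cccc3N3CCNCC3)CN2)[C@H]2CCCc3cccnc32)CC1` gives 498 nM.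

Compound 2 has the lowest number of the three and so the strongest inhibition here. The step of a 51-fold lower number from compound 1 to compound 2 (1.71 log units; beyond the scatter) shows how much the drawn configuration matters, which rests on (the fact that compounds 1 and 2 differ only in the configuration as drawn). The step of an 82-fold higher number from compound 2 to compound 3 (1.91 log units; beyond the scatter) shows that a large group on the chain carbon bound to the amine nitrogen costs a great deal. Compound 4 `CN(C[C@H]1Cc2c(cccc2N2CCNC(C)(C)C2)CN1)[C@H]1CCCc2cccnc21` carries a change of a different kind: 3,3-dimethylpiperazin-1-yl in place of piperazin-1-yl on an aromatic carbon. Neither measured step touches this ring, so there is no direct guide; the change is small in size, and only a modest shift, perhaps a slight loss, is expected. Compound 4 is estimated at 10 nM, between 3 nM and 40 nM, a step of a 1.6-fold higher number from compound 2 to compound 4 (0.22 log units; within the scatter).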

Compound 4, half-maximal inhibitory concentration: 33.9 nM
The estimate for compound 4 lay 3.4-fold (0.53 log units) below the measured number, and the stated range covers the measured number.
By their numbers in this assay, from the lowest: compound 2; then compound 4; then compounds 1 and 3 (each within the scatter of the next).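

In this assay, 3,3-dimethylpiperazin-1-yl in place of piperazin-1-yl on the aromatic carbon gives a 5.6-fold higher number from compound 2 to compound 4 (0.75 log units; beyond the scatter), so this position does respond to a change in the ring. The step is modest, whereas the two earlier changes, made elsewhere in the molecule, gave large steps. Nothing measured here explains why the dimethyl ring gives the higher number. From the compounds shown here alone, whether one methyl group alone would give a similar step remains open, and so does the effect of a morpholine ring at this position.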